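The compounds below may be only part of what the source reports. "The series", "measured", "known", "first", "only" and "open" are said of these compounds alone.

Compound 2, `O=C(CCc1cccc2c1B(O)OC2)NC1CCCCC1`, is an amide of the shared core carrying a cyclohexyl group on its nitrogen. In a functional assay on MDA-MB-231 cells (Homo sapiens) for antiproliferative activity, read by MTT assay, with a stated time of 72 h (on this read-out higher numbers stand for weaker inhibition and lower numbers for stronger inhibition), compound 2 gives > 100000 nM, which is a limit of the assay rather than a number. The parent acid, compound 1 with structure `O=C(O)CCc1cccc2c1B(O)OC2`, also reaches only that limit, > 100000 nM, so the step that the two limits leave unreadable from compound 1 to compound 2 cannot be read; both sit at the limit of > 100000 nM in this assay, at which 2 of the 3 values shown sit. Compound 3, `O=C(CCc1cccc2c1B(O)OC2)Nc1ccccc1`, carries a phenyl group on the same nitrogen and gives 230 nM in this assay, a clear number.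

Compound 4 is `O=C(CCc1cccc2c1B(O)OC2)NCc1ccccc1`. It differs from compound 2 in one place: benzyl in place of cyclohexyl on an amide-type nitrogen. The measured step that bears most directly on this change is an at least 430-fold lower number from compound 2 to compound 3 (2.63 log units; beyond the scatter), where an aromatic ring replaced the same cyclohexyl and the number dropped sharply; the step of an at least 430-fold lower number from compound 1 to compound 3 (2.63 log units; beyond the scatter) points the same way. A benzyl group brings the aromatic ring of compound 3 but keeps it one carbon further from the nitrogen, so a fall in the number is expected, though its size is uncertain.

Compound 4 is therefore estimated at 2000 nM in this assay, with a range from 300 nM to 30000 nM. That estimate means a step of an at least 50-fold lower number from compound 2 to compound 4 (1.69 log units; beyond the scatter), expected to lie beyond the scatter.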

Compound 4, half-maximal inhibitory concentration: > 100000 nM
Compound 4 gave a limit, no number; the forecaster's own chance of this, stated with the estimate: 25%; at least 50-fold (1.69 log units) between middle value and limit.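

An aromatic ring on the amide-type nitrogen is not enough on its own: benzyl and phenyl each carry one, yet in this assay benzyl in place of phenyl gives an at least 430-fold higher number from compound 3 to compound 4 (2.63 log units; beyond the scatter). Compound 1, compound 2 and compound 4 all stop at a limit of the assay, not a number: the limit of > 100000 nM in this assay, at which 3 of the 4 values shown sit. The steps among these three compounds cannot be read, so the acid, the cyclohexyl amide and the benzyl amide cannot be ranked against one another, and compound 3, with its phenyl group, is the only one of the four that gives a number.

The compounds shown leave open whether the number of compound 3 survives a small group such as fluoro or methoxy on its phenyl ring, or the replacement of that ring by a pyridyl ring. They also leave open whether a methyl group in place of the amide hydrogen of compound 3 keeps its number, and whether a longer chain such as phenethyl on the nitrogen stays at the limit as benzyl does.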